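The source may report more compounds than this note shows. Statements on the series, on what has been measured and on what is new or still open speak of the compounds shown alone.

Compound 1 `Cc1nc(S(C)(=O)=O)ccc1Oc1ncnc(OC2CCN(C(=O)O[C@@H](C)CF)CC2)c1F`: 84%
Compound 2 `Cc1nc(S(C)(=O)=O)ccc1Oc1ncnc(OC2CCN(C(=O)SC(C)C)CC2)c1F`: 81%

Both readings come from a functional assay on isolated protein for inhibition of Glucose-dependent insulinotropic receptor (Rattus norvegicus), read by HTRF and cAMP accumulation; on this read-out lower numbers stand for smaller maximal responses and higher numbers for larger maximal responses. On these two numbers compound 2 sits alongside compound 1, since a number 3 percentage points lower from compound 1 to compound 2 (within the scatter) stays within the scatter. Compound 3 `Cc1nc(S(C)(=O)=O)ccc1Oc1ncnc(OC2CCN(C(=O)SC3CCC3)CC2)c1F` is not yet measured. It differs from compound 2 by cyclobutyl in place of isopropyl on a sulfur, the sulfur in question carrying the carbonyl carbon as its other neighbour. Among the compounds with values here, the one measured step that bears on this, a number 3 percentage points lower from compound 1 to compound 2 (within the scatter), exchanged the entire group on the carbonyl carbon without moving beyond the scatter, so for this smaller exchange no step beyond the scatter is expected: a number 1 percentage points lower from compound 2 to compound 3 (within the scatter). Compound 3 is therefore estimated at 80%, with a range from 70% to 90%.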

Compound 3, largest response reached (reported as efficacy), in percent of the reference or control that the assay uses: 81%
Beside the measured number, compound 3's estimate is 1 percentage points below it, within the range that was stated.
By their numbers in this assay, from the lowest: compounds 2, 3 and 1 (each within the scatter of the next).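

With cyclobutyl in place of isopropyl on the sulfur, this position now carries a ring, and this assay shows no change at the digits printed from compound 2 to compound 3 (within the scatter). Replacing the whole group on the carbonyl carbon gives a number 3 percentage points lower from compound 1 to compound 3 (within the scatter), so at this position a four-membered carbon ring leaves the maximal response within the scatter of both open-chain groups. Nothing available explains why this response holds. Still open, from the compounds shown here alone, is whether a larger ring such as cyclohexyl, or a ring carrying an amine, on the same sulfur would keep the response within that scatter.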